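This account rests on a few compounds, and the source may have more. Where it says the series, first, only, none or still open, it means among the compounds named here.

The measured compounds in an ADME assay on MT4 cells (Homo sapiens) for cytotoxicity; a higher number here means that more compound is tolerated, a lower number that less compound is tolerated:

Compound 1, `CCNC(=S)Nc1cccc(C(F)(F)F)c1`, gives > 100000 nM, which is a limit of the assay and not a number.
Compound 2, `Cc1ccc(NC(=S)Nc2cccc(C(F)(F)F)c2)cc1Cl`, gives 20000 nM.
Compound 3, `O=[N+]([O-])c1ccc(NC(=S)Nc2cccc(C(F)(F)F)c2)cc1`, gives 9200 nM.

Compound 1 therefore stands only at the limit of > 100000 nM in this assay, at which 1 of the 3 values shown sits, so its true position is not known. Compound 4, `FC(F)(F)c1cccc(NC(=S)Nc2ccccc2Br)c1`, differs from compound 1 in one place: 2-bromophenyl in place of ethyl on an amide-type nitrogen. Within the data shown here, no step between measured compounds connects such a change to a measured shift, so the size of the step in this assay can only be expected, not read off. Compound 2 and compound 3 both come out as measured numbers in this assay, and compound 4 is built more like them than like compound 1. Compound 4 is therefore expected to be tolerated less well than compound 1. The expected step of an at least 6.6-fold lower number from compound 1 to compound 4 (0.82 log units; beyond the scatter) is anticipated to lie beyond the scatter, in the direction of less compound tolerated, though its full size cannot be fixed while compound 1 sits at a limit. Compound 4 is estimated at 15000 nM, with a range from 5000 nM to 50000 nM.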

Compound 4, half-maximal cytotoxic concentration: 36000 nM
Compound 4: the middle estimate sits 2.4-fold (0.38 log units) below what was measured; the range from low to high includes it.
By their numbers in this assay, from the lowest: compound 3; then compounds 2 and 4 (each within the scatter of the next). At a limit, above all of these: compound 1.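

Setting 2-bromophenyl in place of ethyl on an amide-type nitrogen gives, in this assay, an at least 2.7-fold lower number from compound 1 to compound 4 (0.44 log units; beyond the scatter). Among these compounds, this is the first step that ties a single change at this place to a shift beyond the scatter, and it shows that the number falls when the six-membered aromatic ring enters in place of the short chain. Compound 1 stands at a limit and not at a number, so the step gives only a lower bound on the change, and its full size remains unknown: the limit of > 100000 nM in this assay, at which 1 of the 4 values shown sits.

Going by these compounds, whether the lower number follows the aromatic ring or the bromine stays open, and a plain phenyl at the same place would separate the two. Equally open, on these data alone, is whether a longer chain such as butyl, which carries no ring, would lower the number as well.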